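The source may report more compounds than this note shows. Statements on the series, on what has been measured and on what is new or still open speak of the compounds shown alone.

Measured compounds:
compound 1 `Cc1cccc(-n2nncc2CN2C(=O)C3(C(C#N)=C(N)Oc4c3c3nc5ccccc5nc3c3ccccc43)c3ccccc32)c1`, 39600 nM
compound 2 `N#CC1=C(N)Oc2c(c3nc4ccccc4nc3c3ccccc23)C12C(=O)N(Cc1cnnn1-c1ccc(Cl)cc1)c1ccccc12`, > 50000 nM

Compound 1 `Cc1cccc(-n2nncc2CN2C(=O)C3(C(C#N)=C(N)Oc4c3c3nc5ccccc5nc3c3ccccc43)c3ccccc32)c1` is one of two compounds tested in a functional assay on A549 cells (Homo sapiens) for antiproliferative activity, read by MTT assay, with a stated time of 48 h; on this read-out lower numbers stand for stronger inhibition and higher numbers for weaker inhibition. In this assay, among the measured compounds shown here, compound 1 gives 39600 nM, the only numerical value among the two. Compound 2 `N#CC1=C(N)Oc2c(c3nc4ccccc4nc3c3ccccc23)C12C(=O)N(Cc1cnnn1-c1ccc(Cl)cc1)c1ccccc12` in this assay reaches only a limit, > 50000 nM, and it stands at that limit (the limit of > 50000 nM in this assay, at which 1 of the 2 values shown sits). For the measured compounds named here, the single computed step, an at least 1.2-fold higher number from compound 1 to compound 2 (0.10 log units; that floor lies within the scatter), comes from putting 4-chlorophenyl in place of 3-methylphenyl on an aromatic nitrogen, and its floor lies within the scatter.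

Compound 3 `N#CC1=C(N)Oc2c(c3nc4ccccc4nc3c3ccccc23)C12C(=O)N(Cc1cnnn1-c1cccc(Cl)c1)c1ccccc12` differs from compound 1 by chloro in place of methyl on an aromatic carbon. This resembles the measured step of an at least 1.2-fold higher number from compound 1 to compound 2 (0.10 log units; that floor lies within the scatter) in that chloro enters where methyl stood, though there the entering group was 4-chlorophenyl rather than 3-chlorophenyl. That step gave no change beyond the scatter, so no change beyond the scatter is expected here either, with some chance that this assay returns only a limit. Compound 3 is therefore estimated at about 45000 nM in this assay, between 20000 nM and 100000 nM. This estimate means the expected step of a 1.1-fold higher number from compound 1 to compound 3 (0.06 log units; within the scatter).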

Compound 3, half-maximal inhibitory concentration: 32600 nM
Estimate against measurement, compound 3: 1.4-fold (0.14 log units) above, and the stated range covers the measured number.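

In this assay, the change from 3-methylphenyl to 3-chlorophenyl gives a 1.2-fold lower number from compound 1 to compound 3 (0.08 log units; within the scatter), so with the substituent kept at the same place on the ring, chloro in place of methyl leaves no change beyond the scatter, whereas the earlier step had altered both the group and its place. The comparison of the two chlorophenyl compounds gives an at least 1.5-fold lower number from compound 2 to compound 3 (0.18 log units; that floor lies within the scatter), the first view of chloro at two places on this ring, yet it does not establish a difference between 3-chlorophenyl and 4-chlorophenyl. Compound 2 remains a limit and not a number, so this comparison offers only a floor: the limit of > 50000 nM in this assay, at which 1 of the 3 values shown sits.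

The compounds shown carry only methyl or chloro on this phenyl ring, so it remains open whether an amine, a carboxylic acid or a methoxy group at the same place would move the number beyond the scatter. Going by these compounds, it also remains open how the read-out would respond to a change outside this ring, such as replacing the nitrile on the shared core with a carboxamide.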